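Swapping a benzyl ring on two related cores

The source may hold more compounds than are shown below. What is called first, only, known or untested is meant among the compounds shown, and "the series" means these compounds.

Compound 1 `Cc1ccc(NC(=S)NC(=O)c2ccc(OCc3cccc(Cl)c3)cc2)cc1-c1nc2ccccc2[nH]1` and compound 2 `Cc1ccc(NC(=S)NC(=O)c2ccc(OCc3ccc(C(F)(F)F)cc3)cc2)cc1-c1nc2ccccc2[nH]1` share one core, while compound 3 `Cc1ccc(NC(=O)NC(=O)c2ccc(OCc3cccc(Cl)c3)cc2)cc1-c1nc2ccccc2[nH]1` and compound 4 `Cc1ccc(NC(=O)NC(=O)c2ccc(OCc3ccc(C(F)(F)F)cc3)cc2)cc1-c1nc2ccccc2[nH]1` share another; the difference between the two cores is not broken down here. In a functional assay on HT-29 cells (Homo sapiens) for inhibition, read by MTT assay, with a stated time of 48 h (a higher number here means a weaker inhibitor, a lower number a stronger inhibitor), compound 1 gives 35300 nM. Changing it to compound 2 means (4-(trifluoromethyl)phenyl in place of 3-chlorophenyl on a saturated chain carbon bound to an oxygen on an aromatic ring), and the result, a 2.0-fold lower number from compound 1 to compound 2 (0.30 log units; within the scatter), is a modest move. In this assay compound 2 gives 17600 nM. On the second core, compound 3 gives 15400 nM in this assay, a number within the scatter of compound 2 and lower than that of compound 1.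

Compound 4 is not yet measured. It differs from compound 3 by 4-(trifluoromethyl)phenyl in place of 3-chlorophenyl on a saturated chain carbon bound to an oxygen on an aromatic ring. This is the same change made from compound 1 to compound 2, with the same place on both cores, and it is seen only that one time among the measured pairs. Going by the values given here, the expected step from compound 3 to compound 4 is taken to be about the size of the one from compound 1 to compound 2, because of a 2.0-fold lower number from compound 1 to compound 2 (0.30 log units; within the scatter), so a 1.7-fold lower number from compound 3 to compound 4 (0.23 log units; within the scatter) is estimated. Since that one example lies within the usual scatter, the expectation is held loosely. Compound 4 is expected to give 9000 nM in this assay, with a likely span from 4000 nM to 22000 nM.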

Compound 4, half-maximal inhibitory concentration: 7830 nM
For compound 4 the middle estimate is 1.1-fold (0.06 log units) above the measured one, within the range that was stated.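

In this assay, putting 4-(trifluoromethyl)phenyl in place of 3-chlorophenyl on the second core gives a 2.0-fold lower number from compound 3 to compound 4 (0.29 log units; within the scatter), and the two appearances of this change can be set side by side: the same change on two cores in this assay, a 2.0-fold lower number (0.30 log units; within the scatter) from compound 1 to compound 2 and a 2.0-fold lower number (0.29 log units; within the scatter) from compound 3 to compound 4, 1.0-fold (0.01 log units) apart, within the scatter of two such steps. So, on these two cores, the change came with a step of about the same size, and what was seen on the core of compound 1 carried over to the core of compound 3. This does not show that the change reliably improves the number, since each step on its own lies within the usual scatter, and two pairs cannot show that the agreement would hold on any other core or explain why the steps match.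

The swap alters both the group carried by the ring and where that group sits, so the compounds shown cannot separate these two parts of the change. Also open, from the compounds shown here alone, is whether a different group on the ring, such as an amine or a carboxylic acid, or a longer chain in place of the single carbon bound to the oxygen, would give matching steps on both cores.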